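The compounds below may be only part of what the source reports. "The series", "measured", "known", "first", "only" and "open" are said of these compounds alone.

Compound 1 `CC#CC(CC(=O)O)c1ccc(OCC2COc3ccc(Cl)cc3O2)cc1` has both stereocentres drawn without configuration, and in a functional assay on HEK293 cells for agonist activity at Free fatty acid receptor 1 (Homo sapiens), read by fluorescence and calcium flux, with a stated time of 10 min (a lower number here means a smaller maximal response, a higher number a larger maximal response), compound 1 gives 104%. Compound 2 `CC#C[C@@H](CC(=O)O)c1ccc(OC[C@H]2COc3ccc(Cl)cc3O2)cc1` fixes both centres, and in this assay compound 2 gives 86%, the step being a number 18 percentage points lower from compound 1 to compound 2 (beyond the scatter). Compound 3 `CC#C[C@H](CC(=O)O)c1ccc(OC[C@H]2COc3ccc(Cl)cc3O2)cc1` keeps the ring centre of compound 2 and flips the chain centre, and in this assay compound 3 gives 47%, the lowest of the three. That step, a number 39 percentage points lower from compound 2 to compound 3 (beyond the scatter), rests on configuration alone because of the fact that compounds 2 and 3 differ only in the configuration as drawn, and against compound 1 it reads a number 57 percentage points lower from compound 1 to compound 3 (beyond the scatter). Compound 4 `CC#C[C@H](CC(=O)O)c1ccc(OC[C@@H]2COc3ccc(Cl)cc3O2)cc1` follows from compound 3 by the two compounds have the same atoms and bonds and differ only in configuration as drawn: 1 of 2 stereo elements differ; a stereocentre at a saturated ring carbon is drawn S in compound 3 and R in compound 4. Going by the values given here, no measured step changes the ring centre on its own, so the direction is open and the scatter wide. Compound 4 is expected to give 55%, between 25% and 90%, an expected step of a number 8 percentage points higher from compound 3 to compound 4 (within the scatter).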

Compound 4, largest response reached (Emax), in percent of the reference or control that the assay uses: 41%
For compound 4 the middle estimate is 14 percentage points above the measured one; the measured number falls inside the stated range.
By their numbers in this assay, from the lowest: compounds 4 and 3 (each within the scatter of the next); then compound 2; then compound 1.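

Changed on its own, the ring centre gives a number 6 percentage points lower from compound 3 to compound 4 (within the scatter) in this assay, so with the chain centre drawn R, this inversion has no effect that stands out from the scatter. Inverting both centres to reach the mirror image gives a number 45 percentage points lower from compound 2 to compound 4 (beyond the scatter), which points to the chain centre as the one that matters here. The step of a number 63 percentage points lower from compound 1 to compound 4 (beyond the scatter) cannot be read as one change, as compound 1 has neither centre defined.

On these data alone, whether the ring centre stays as silent with the chain centre drawn S remains open. So does whether the chain-centre gap survives with a fluorine in place of the chlorine.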